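Swapping the Outer Phenyl Ring for Thiophene in Compound 1

The source may report more compounds than this note shows. Statements on the series, on what has been measured and on what is new or still open speak of the compounds shown alone.

Measured so far in a functional assay on SK-BR-3 cells (Homo sapiens) for cytotoxicity, read by colorimetric assay, with a stated time of 72 h; a higher number here means a weaker inhibitor, a lower number a stronger inhibitor:
compound 1 `OC[C@H](NC[C@H]1NC[C@H](O)[C@@H]1O)c1ccc(-c2ccccc2)cc1`: > 200000 nM, a limit of the assay rather than a number.
compound 2 `OC[C@H](NC[C@H]1NC[C@H](O)[C@@H]1O)c1ccc(-c2ccc(C(F)(F)F)cc2)cc1`: 48000 nM.

Compound 1 thus stands only at a limit (the limit of > 200000 nM in this assay, at which 1 of the 2 values shown sits), with no measured number of its own. Compound 3 `OC[C@H](NC[C@H]1NC[C@H](O)[C@@H]1O)c1ccc(-c2ccsc2)cc1` differs from it by thiophen-3-yl in place of phenyl on an aromatic carbon. For the measured compounds named here, the single measured step, an at least 4.1-fold lower number from compound 1 to compound 2 (0.61 log units; beyond the scatter), adds a group to the outer ring rather than replacing that ring, so it does not bear directly on this change. Going by the values given here, with no step that speaks to a ring swap, compound 3 is expected to remain near the limit, an expected step of an at least 1.3-fold lower number from compound 1 to compound 3 (0.12 log units; that floor lies within the scatter). The estimate for compound 3 is 150000 nM, within 40000 nM to 400000 nM.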

Compound 3, half-maximal inhibitory concentration: "not active" (no number reported)
Compound 3 has no reported number here; there is nothing to compare the estimate with.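

For the compounds shown here, compound 3 is reported in this assay only as not active, with no number, and no step from compound 1 to compound 3 can be read. On these data alone, whether thiophen-3-yl in place of phenyl changes cytotoxicity at all stays open.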